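Trifluoromethyl added to the core of compound 2

The source may hold more compounds than are shown below. What is called first, only, known or untested is meant among the compounds shown, and "the series" means these compounds.

Of the compounds shown here, three have been measured in an assay for inhibition of Tryptophan 2,3-dioxygenase (Homo sapiens), with stated times of 10 min and 60 min, tested at 10 uM (a lower number here means a weaker effect, a higher number a stronger effect of the compound at the concentration tested), so far. Compound 1 `O=[N+]([O-])c1cccc(CNc2cc(C(F)(F)F)cc3[nH]ncc23)c1` gives 60% in this assay, compound 2 `O=[N+]([O-])c1ccccc1CNc1cccc2[nH]ncc12` gives 45%, and compound 3 `FC(F)(F)c1cc(NC[C@@H]2CCCCN2)c2cn[nH]c2c1` gives 64%. Compound 2 therefore stands lowest of the three numbers: its nearest neighbour is compound 1, whose number is higher by more than the usual scatter, and the furthest is compound 3, whose number is higher still, also beyond the scatter.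

The next compound, compound 4 `O=[N+]([O-])c1ccccc1CNc1cc(C(F)(F)F)cc2[nH]ncc12`, differs from compound 2 in one place only: trifluoromethyl in place of hydrogen on an aromatic carbon. Among the compounds with values here, no step between two measured compounds isolates this change, so its size can only be guessed. Both compounds that carry a trifluoromethyl group on the shared core, compound 1 and compound 3, sit above compound 2 in this assay, though each also differs from compound 2 elsewhere, so neither is a clean guide.

On that basis an upward step is expected for compound 4, of about a number 13 percentage points higher from compound 2 to compound 4 (beyond the scatter) in this assay, beyond the scatter but modest. Compound 4 is estimated to give 58% in this assay, with a range from 45% to 72%.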

Compound 4, a percentage reported as inhibition, at one concentration (the size of the read-out at that concentration, not a potency): 89%
The estimate for compound 4 lay 31 percentage points below the measured number, and the stated range ends below it.
By their numbers in this assay, from the lowest: compound 2; then compounds 1 and 3 (each within the scatter of the next); then compound 4.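

In this assay, within the data shown here, the step of a number 44 percentage points higher from compound 2 to compound 4 (beyond the scatter) gives the first clean reading of this change, trifluoromethyl in place of hydrogen on an aromatic carbon of the shared core with the rest of the structure unchanged, and it is large. Compound 1 and compound 3 also carry trifluoromethyl at this place but differ from compound 2 elsewhere, so they could not show how much this one change alone moves the read-out; with it, compound 4 now stands above all three earlier compounds. No measurement shown here bears on why the step is so large.

Going by these compounds, whether another group at this place, such as a methyl group, a chlorine atom or a nitrile, would give a step of similar size remains open. It is also open whether trifluoromethyl would give a step of this size with the side chain of compound 3 or of compound 1, since neither has a partner with hydrogen at this place among the compounds shown, and a read-out at one concentration does not give a potency.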